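Ethylamino to anilino in the clearance series

The source may hold more compounds than are shown below. What is called first, only, known or untested is meant among the compounds shown, and "the series" means these compounds.

Values in an ADME assay (liver) for metabolic stability, with Liver microsome (Rattus norvegicus) as the target, using microsomes and NADPH, with a stated time of 30 min, at 37 degrees C, tested at 1 uM; on this read-out lower numbers stand for slow clearance and higher numbers for fast clearance:
- compound 1 `Nc1ccc(S(=O)(=O)c2ccc(-c3ncc(C(O)(C(F)(F)F)C(F)(F)F)cc3Cl)cc2)cn1`: 18 mL.min-1.g-1
- compound 2 `CC#Cc1cc(C(O)(C(F)(F)F)C(F)(F)F)cnc1-c1ccc(S(=O)(=O)c2ccc(N)nc2)cc1`: 177 mL.min-1.g-1
- compound 3 `CCNc1nc(S(=O)(=O)c2ccc(N)nc2)ccc1-c1ccc(C(C)(O)C(F)(F)F)cn1`: 42 mL.min-1.g-1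

Compound 3, at 42 mL.min-1.g-1, is second highest of the three in this assay. Its value lies over that of compound 1 and under that of compound 2, and both gaps are beyond the scatter.

Compound 4 `CC(O)(c1ccc(-c2ccc(S(=O)(=O)c3ccc(N)nc3)nc2Nc2ccccc2)nc1)C(F)(F)F` is the next to be read. It differs from compound 3 by phenyl in place of ethyl on a nitrogen on an aromatic ring, which reads as ethylamino to anilino.

Among the compounds with values here, no measured step covers a change on this nitrogen. Within the data shown here, the only single-place step available is a 9.8-fold higher number from compound 1 to compound 2 (0.99 log units; beyond the scatter), with prop-1-yn-1-yl in place of chloro on an aromatic carbon. That is a different group in a different place, so it gives only a loose guide to direction and size. A rise is therefore expected, but a smaller one than in that step, and the range is kept wide.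

The expected change is a 2.1-fold higher number from compound 3 to compound 4 (0.33 log units; beyond the scatter).

For compound 4 the estimated value is 90 mL.min-1.g-1, with an expected range of 35 mL.min-1.g-1 to 220 mL.min-1.g-1.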

Compound 4, intrinsic clearance in microsomes: 100 mL.min-1.g-1
For compound 4 the middle estimate is 1.1-fold (0.05 log units) below the measured one; measured number inside the range.
By their numbers in this assay, from the lowest: compound 1; then compound 3; then compounds 4 and 2 (each within the scatter of the next).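

Within the data shown here, this is the first measured step on a nitrogen on an aromatic ring: in this assay, phenyl in place of ethyl gives a 2.4-fold higher number from compound 3 to compound 4 (0.38 log units; beyond the scatter) and so places the read-out at this position beyond the scatter. The number therefore responds to the group carried on this nitrogen, and the change is in the direction of faster clearance on this read-out. Neither the leaving ethyl nor the entering phenyl carries a hydrogen-bond donor or acceptor, so the step records an exchange of one carbon group for a larger one containing a six-membered aromatic ring, and nothing available gives a measured reason for the rise.

A single step cannot separate the effect of the added carbon count from that of the aromatic ring, and a cyclohexyl or a longer chain such as butyl on the same nitrogen would be needed to tell these apart. Going by these compounds, how a pyridyl ring or a free amine at this place would read in this assay also stays open, as does whether the step carries over to cores bearing chloro or prop-1-yn-1-yl.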